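Swapping one fluoro for hydrogen

The source may hold more compounds than are shown below. What is called first, only, known or untested is meant among the compounds shown, and "the series" means these compounds.

compound 1 `COc1c(NC(=O)c2ccc(NS(C)(=O)=O)cc2)cc(N2CCC(=O)NC2=O)cc1C(C)(C)C` gives 32800 nM in the first test
compound 2 `COc1c(/C=C/c2ccc(NS(C)(=O)=O)c(F)c2)cc(-n2ccc(=O)[nH]c2=O)cc1C(C)(C)C` gives 15500 nM in the same test

In a physicochemical assay for solubility, at pH 7.2 (on this read-out higher numbers stand for higher solubility and lower numbers for lower solubility), compound 2 gives 15500 nM as the lower of the two numbers, and compound 1 stands higher by more than the usual scatter. Compound 3 (`COc1c(/C=C/c2ccc(NS(C)(=O)=O)cc2)cc(-n2ccc(=O)[nH]c2=O)cc1C(C)(C)C`) differs from compound 2 in one place: hydrogen in place of fluoro on an aromatic carbon with hydrogen in place of fluoro on an aromatic carbon. Going by the values given here, no measured pair of compounds shows this swap. In this assay no change beyond the scatter is expected, with a slight lean upward. The estimated 1.2-fold higher number from compound 2 to compound 3 (0.06 log units; within the scatter) is expected to be small. Compound 3 is estimated at 18000 nM within a range from 7500 nM to 40000 nM on this measure.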

Compound 3, solubility: 20700 nM
Beside the measured number, compound 3's estimate is 1.2-fold (0.06 log units) below it, and the stated range covers the measured number.
By their numbers in this assay, from the lowest: compounds 2, 3 and 1 (each within the scatter of the next, the first and the last beyond it).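

In this assay hydrogen in place of fluoro on this aromatic carbon, ortho to a methanesulfonamido group, gives a 1.3-fold higher number from compound 2 to compound 3 (0.13 log units; within the scatter) and so leaves the two compounds indistinguishable on this measure. Going by these compounds alone, this is the first pair that isolates this position, since compound 1 and compound 2 differ in more than one place. No supporting measurement is available to explain this result. As far as these compounds go, whether a chloro, a methoxy or an amine on the same carbon would also stay within the scatter remains open, as one pair cannot show how this position responds to other groups.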